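Chloro-to-hydrogen step on the acylsulfonamide aryl ring

The source may hold more compounds than are shown below. What is called first, only, known or untested is meant among the compounds shown, and "the series" means these compounds.

Measured compounds:
compound 1 `Cc1ncc([N+](=O)[O-])n1CC(=O)NS(=O)(=O)c1ccc(Cl)cc1` — 2.47 ug/mL
compound 2 `O=C(Cc1ccc(F)cc1)NS(=O)(=O)c1ccc(Cl)cc1` — 6.28 ug/mL

In a functional assay on A549 cells (Homo sapiens) for antiproliferative activity, read by MTT assay, with a stated time of 48 h (on this read-out lower numbers stand for stronger inhibition and higher numbers for weaker inhibition), compound 1 gives 2.47 ug/mL, the lowest of the two numbers; compound 2 gives 6.28 ug/mL, a higher number lying beyond the scatter. Compound 3 `Cc1ncc([N+](=O)[O-])n1CC(=O)NS(=O)(=O)c1ccccc1` differs from compound 1 by hydrogen in place of chloro on an aromatic carbon. For the measured compounds named here, no measured pair shows this change, so its step is unmeasured here. A modest move toward a higher number is expected in this assay, at or just beyond the edge of the scatter, as a 1.7-fold higher number from compound 1 to compound 3 (0.23 log units; within the scatter). Compound 3 is therefore estimated at 4.2 ug/mL, within 1.8 ug/mL to 10 ug/mL.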

Compound 3, half-maximal inhibitory concentration: 3.96 ug/mL
Estimate against measurement, compound 3: 1.1-fold (0.03 log units) above, within the range that was stated.
By their numbers in this assay, from the lowest: compounds 1, 3 and 2 (each within the scatter of the next, the first and the last beyond it).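

In this assay, for the compounds shown here, the change from 4-chlorophenyl to phenyl gives a 1.6-fold higher number from compound 1 to compound 3 (0.20 log units; within the scatter), the first reading at this place on the ring. On the core of compound 1, the chloro can therefore give way to hydrogen without a step beyond the scatter. No available data bear on why this step is of this size.

Open, from the compounds shown here alone, is how a methoxy group, an amine or a carboxylic acid would read at this place, para to a large group. Also open, going by these compounds, is whether the same chloro-to-hydrogen step would hold with the other acyl side of compound 2.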